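Dichlorophenyl regioisomer in the benzylcarbamate series

The source may hold more compounds than are shown below. What is called first, only, known or untested is meant among the compounds shown, and "the series" means these compounds.

The shared core is seen in compound 1 `CCC(COc1cccc(C#N)c1)OC(=O)NCc1ccccc1` and compound 2 `CCC(COc1cc(Cl)ccc1Cl)OC(=O)NCc1ccccc1`. In an assay for inhibition of zeta-carotene desaturase, chloroplastic/chromoplastic (Capsicum annuum), using a Dixon plot, with a stated time of 8 h (a higher number here means a weaker inhibitor, a lower number a stronger inhibitor), compound 1 reports only a limit, > 100000 nM. Compound 2 also reports only a limit in this assay, > 100000 nM. The step from compound 1 to compound 2, a step that the two limits leave unreadable from compound 1 to compound 2, thus has no readable size; both values sit at the limit of > 100000 nM in this assay, at which 2 of the 2 values shown sit, so the aryl exchange between them cannot be sized, and compound 2 stands at the limit of this assay, not at a number.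

Compound 3 `CCC(COc1ccc(Cl)c(Cl)c1)OC(=O)NCc1ccccc1` carries 3,4-dichlorophenyl in place of 2,5-dichlorophenyl on an oxygen on a saturated carbon. Going by the values given here, no measured step bears on this rearrangement of the two chlorines; the single measured step in this assay is unreadable, and nothing in the data points in either direction. With both measured values at the limit, the expected step in this assay is a number no higher from compound 2 to compound 3 (the limit leaves the size open), no readable change, and a further limit is the most likely outcome. Compound 3 is expected in this assay at 100000 nM, within the range 30000 nM to 300000 nM.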

Compound 3, half-maximal inhibitory concentration: > 100000 nM
Compound 3 gave a limit, no number (the forecaster's own chance of this, stated with the estimate: 85%); the middle value sits exactly at the limit.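

Compound 3 gives only a limit in this assay, > 100000 nM. No new step can be read from compound 3 to either compound 1 or compound 2. The compounds shown leave open whether any aryl exchange on the shared core can give a readable value in this assay, since all the results stay at one limit: the limit of > 100000 nM in this assay, at which 3 of the 3 values shown sit.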